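The source may report more compounds than this note shows. Statements on the series, on what has been measured and on what is new or still open speak of the compounds shown alone.

Measured compounds:
- Compound 1, `COCc1cc(O)c(O)c(Br)c1`: in a functional assay on DLD-1 cells (Homo sapiens) for cytotoxicity, read by MTT assay, with a stated time of 96 h (on this read-out higher numbers stand for weaker inhibition and lower numbers for stronger inhibition), compound 1 gives 35300 nM.
- Compound 2, `COCc1cc(O)c(O)c(Br)c1Br`: in this assay compound 2 gives 14600 nM.

Within the data shown here, of these two numbers, compound 1 has the higher one, meaning the weaker inhibition; its only neighbour is compound 2, reached by a 2.4-fold lower number from compound 1 to compound 2 (0.38 log units; beyond the scatter) through bromo in place of hydrogen on an aromatic carbon. Compound 3, `CCOCc1cc(O)c(O)c(Br)c1`, differs from compound 1 by methyl in place of hydrogen on a saturated chain carbon bound to an oxygen on a saturated carbon. Among the measured compounds shown here, the single measured step touches an aromatic carbon, whereas the change leading to compound 3 sits on a saturated chain carbon bound to an oxygen on a saturated carbon, so no measured step bears directly on it. With nothing comparable to lean on, the step from compound 1 to compound 3 is expected to be a 1.0-fold lower number from compound 1 to compound 3 (0.00 log units; within the scatter), that is, no change beyond the scatter. Compound 3 is therefore estimated at 35000 nM, with a range from 15000 nM to 80000 nM.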

Compound 3, half-maximal inhibitory concentration: 35100 nM
For compound 3 the middle estimate is 1.0-fold (0.00 log units) below the measured one; the measured number falls inside the stated range.
By their numbers in this assay, from the lowest: compound 2; then compounds 3 and 1 (each within the scatter of the next).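

Swapping methoxymethyl for ethoxymethyl gives a 1.0-fold lower number from compound 1 to compound 3 (0.00 log units; within the scatter) in this assay, so compounds 1 and 3 cannot be told apart on this read-out. The earlier step concerned only an aromatic carbon, whereas this one shows that a methyl on a saturated chain carbon bound to an oxygen is accepted here, with the cytotoxicity number neither better nor worse beyond the scatter. No measurement is available to explain this match.

As far as these compounds go, a single added methyl is only one point, so it remains open whether a longer chain such as propoxymethyl, or a chain carrying an amine, would also match compound 1. Among these compounds, it also remains open whether adding a second bromo to compound 3 would give a step like the one seen from compound 1 to compound 2.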